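The compounds below may be only part of what the source reports. "The series", "measured", "known", "first", "only" and "open" are said of these compounds alone.

Three compounds have been measured in an assay on lung parenchyma for displacement of a labelled ligand from cysteinyl leukotriene receptor 1 (Cavia porcellus); a higher number here means a weaker inhibitor, a lower number a stronger inhibitor:

Compound 1 `COc1cc(C(=O)NS(=O)(=O)c2ccccc2C)ccc1Cc1cn(C)c2ccc(C(=O)NCC(C)C(F)(F)F)cc12` gives 12 nM.
Compound 2 `COc1cc(C(=O)NS(=O)(=O)c2ccccc2C)ccc1Cc1cn(C)c2ccc(C(=O)NCCC(C)C(F)(F)F)cc12` gives 7.3 nM.
Compound 3 `COc1cc(C(=O)NS(=O)(=O)c2ccccc2C)ccc1Cc1cn(C)c2ccc(C(=O)NCC(C)CC(F)(F)F)cc12` gives 0.57 nM.

Compound 3 stands at the lowest number of the three, and both its steps to the others lie beyond the scatter: a 21-fold lower number from compound 1 to compound 3 (1.32 log units; beyond the scatter) and a 13-fold lower number from compound 2 to compound 3 (1.11 log units; beyond the scatter). The step of a 1.6-fold lower number from compound 1 to compound 2 (0.22 log units; within the scatter), by contrast, stays within the scatter.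

Compound 4 `CCC(CNC(=O)c1ccc2c(c1)c(Cc1ccc(C(=O)NS(=O)(=O)c3ccccc3C)cc1OC)cn2C)CC(F)(F)F` is not yet measured. It differs from compound 3 by methyl in place of hydrogen on a saturated chain carbon, three bonds along the chain from an amide-type nitrogen. For the measured compounds named here, no measured step is of this same kind. Going by the values given here, the two large steps in this assay both moved the trifluoromethyl group along the chain, whereas the one step that only lengthened the chain, the step from compound 1 to compound 2, was small. The change to compound 4 keeps the trifluoromethyl group where it stands in compound 3 and adds one carbon at the branch, so the nearest comparison is the small step. The expectation is therefore a step of modest size, a 1.8-fold higher number from compound 3 to compound 4 (0.24 log units; within the scatter), with a slight drift toward a higher number but no firm direction. Compound 4 is expected to give about 1 nM, within a range from 0.3 nM to 3.5 nM.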

Compound 4, inhibition constant: 5.3 nM
Compound 4: the middle estimate sits 5.3-fold (0.72 log units) below what was measured, and the stated range ends below it.
By their numbers in this assay, from the lowest: compound 3; then compounds 4, 2 and 1 (each within the scatter of the next, the first and the last beyond it).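

In this assay this chain carbon proves sensitive to a single added carbon: methyl in place of hydrogen, three bonds along the chain from an amide-type nitrogen, gives a 9.3-fold higher number from compound 3 to compound 4 (0.97 log units; beyond the scatter) and so gives up most of what set compound 3 apart. The earlier large steps all moved the trifluoromethyl group along the chain, whereas this one leaves that group in place and still lies beyond the scatter, so the position of the trifluoromethyl group is not the only thing that counts in this series. The result also places the 1-(2,2,2-trifluoroethyl)propyl compound among the weaker ones, with a 1.4-fold lower number from compound 2 to compound 4 (0.14 log units; within the scatter) staying within the scatter and a 2.3-fold lower number from compound 1 to compound 4 (0.35 log units; beyond the scatter) lying modestly beyond it.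

Nothing available explains the size of this step. A fluorine, a hydroxymethyl group or a longer chain such as propyl on the same carbon would show whether the number keeps rising with the size of the group or depends on what the group is.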